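Adding a group back to compound 2

The compounds below may be only part of what the source reports. "The series", "measured", "known", "first", "only" and "open" are said of these compounds alone.

In a functional assay for inhibition, with Homo sapiens as the target (on this read-out higher numbers stand for weaker inhibition and lower numbers for stronger inhibition), compound 2 `O=C(O)CCNC(=O)c1cc2cc(CCC3CCNCC3)sc2s1` gives 410 nM. Among the measured compounds shown here, this is the higher of the two numbers measured so far, as compound 1 `O=C(NC[C@H](NS(=O)(=O)c1cccnc1)C(=O)O)c1cc2cc(CCC3CCNCC3)sc2s1` gives 8 nM, so compound 2 is the weaker inhibitor of the pair. For the measured compounds named here, only one measured step bears on what comes next. The step of a 51-fold higher number from compound 1 to compound 2 (1.71 log units; beyond the scatter) is large and beyond the scatter, and it puts hydrogen in place of ((pyridin-3-yl)sulfonyl)amino on a saturated chain carbon bound to a carbonyl carbon and a saturated chain carbon.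

Compound 3 `O=C(NCc1ccccc1)N[C@@H](CNC(=O)c1cc2cc(CCC3CCNCC3)sc2s1)C(=O)O` changes that same place in the opposite sense: (benzylcarbamoyl)amino in place of hydrogen on a saturated chain carbon bound to a carbonyl carbon and a saturated chain carbon. Here (benzylcarbamoyl)amino stands in place of hydrogen, so the hydrogen goes but a different group arrives. Going by the values given here, the evidence that a group there matters is a single pair, compound 1 at 8 nM against compound 2 at 410 nM, and no measured compound carries this new group. A large move towards a lower number in this assay is therefore expected, though probably a smaller one than the measured step. The expected size is a 16-fold lower number from compound 2 to compound 3 (1.21 log units; beyond the scatter). The estimated value for compound 3 is 25 nM, with an expected range of 5 nM to 120 nM.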

Compound 3, half-maximal inhibitory concentration: 76 nM
Compound 3: middle estimate off by 3.0-fold (0.48 log units), on the low side; the range from low to high includes it.
By their numbers in this assay, from the lowest: compound 1; then compound 3; then compound 2.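

The gain on this saturated chain carbon does not belong to the (pyridin-3-yl)sulfonyl group alone: in this assay, (benzylcarbamoyl)amino in place of hydrogen gives a 5.4-fold lower number from compound 2 to compound 3 (0.73 log units; beyond the scatter), so a second, quite different group also improves on hydrogen at this place. The two groups are not equal, however: benzylcarbamoyl in place of (pyridin-3-yl)sulfonyl on the amine nitrogen gives a 9.5-fold higher number from compound 1 to compound 3 (0.98 log units; beyond the scatter), which shows that what the nitrogen carries counts, not only that something stands on this carbon. Nothing measured here explains why either group helps or why one does better than the other.

As far as these compounds go, what a plain amino group on this carbon would give, with nothing further on the nitrogen, remains open, and with it how much of the gain belongs to the nitrogen itself and how much to the group it carries. Equally open, from the compounds shown here alone, is whether a methylsulfonyl group on that nitrogen, or a phenyl ring joined through a shorter chain, would land nearer to compound 1 or to compound 3.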